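Trimming the dimethoxyphenyl ketone to a monomethoxyphenyl

The source may hold more compounds than are shown below. What is called first, only, known or untested is meant among the compounds shown, and "the series" means these compounds.

In a functional assay on SW-620 cells (Homo sapiens) for cytotoxicity, read by sulforhodamine B assay, with a stated time of 48 h, tested at 0.1 uM (a lower number here means a stronger effect, a higher number a weaker effect of the compound at the concentration tested), compound 1 `COc1cc(-c2cc(/C=C/C(=O)c3ccc(N)cc3)[nH]n2)cc(OC)c1OC` gives 95%, compound 2 `COc1cc(-c2cc(/C=C/C(=O)c3ccc(Cl)c(Cl)c3)[nH]n2)cc(OC)c1OC` gives 99% and compound 3 `COc1ccc(C(=O)/C=C/c2cc(-c3cc(OC)c(OC)c(OC)c3)n[nH]2)cc1OC` gives 99%. Compound 3 stands level with compound 2 at the digits shown, the two together the highest of the three numbers; the steps between the measured compounds read a number 4 percentage points higher from compound 1 to compound 2 (within the scatter), a number 4 percentage points higher from compound 1 to compound 3 (within the scatter) and no change at the digits printed from compound 2 to compound 3 (within the scatter). Compound 4 `COc1ccc(C(=O)/C=C/c2cc(-c3cc(OC)c(OC)c(OC)c3)n[nH]2)cc1` differs from compound 3 by hydrogen in place of methoxy on an aromatic carbon. Within the data shown here, the one step that touches the same aryl group on the carbonyl carbon, no change at the digits printed from compound 2 to compound 3 (within the scatter), and indeed every measured step lies within the scatter, so no step beyond the scatter is expected in this assay, a number 2 percentage points lower from compound 3 to compound 4 (within the scatter). Compound 4 is therefore estimated at 97%, range 86% to 103%.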

Compound 4, a percentage reported as activity, at one concentration (the size of the read-out at that concentration, not a potency): 97%
Compound 4: middle estimate and measured number agree at the digits printed; low and high end bracket the measured number.
By their numbers in this assay, from the lowest: compounds 1, 4, 2 and 3 (each within the scatter of the next).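

In this assay the methoxy ortho to a methoxy group gives way to hydrogen with a number 2 percentage points lower from compound 3 to compound 4 (within the scatter), so at this concentration the aryl ketone reads alike with one methoxy or two. The 4-methoxyphenyl ketone also shows no step beyond the scatter against the other aryl groups, with a number 2 percentage points lower from compound 2 to compound 4 (within the scatter) and a number 2 percentage points higher from compound 1 to compound 4 (within the scatter). No evidence available here bears on this result.

On these data alone, whether a hydroxy group, a fluorine atom or an unsubstituted phenyl on the carbonyl carbon would read differently stays open. So does the behaviour of all these aryl ketones at other concentrations.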